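Cytotoxicity of nitrofuran triazoles: removing a phenolic hydroxyl

The source may hold more compounds than are shown below. What is called first, only, known or untested is meant among the compounds shown, and "the series" means these compounds.

Compound 3 `COc1cc(Cn2cc(CNC(=O)c3ccc([N+](=O)[O-])o3)nn2)ccc1O` gives 224000 nM in an ADME assay on Vero cells (Chlorocebus sabaeus) for cytotoxicity; on this read-out higher numbers stand for weaker inhibition and lower numbers for stronger inhibition. Compound 1 `O=C(NCc1cn(Cc2ccc(C(F)(F)F)cc2)nn1)c1ccc([N+](=O)[O-])o1` gives 289000 nM and compound 2 `O=C(NCc1cn(Cc2ccc([N+](=O)[O-])cc2)nn1)c1ccc([N+](=O)[O-])o1` gives 291000 nM; all three numbers lie within the scatter of one another. Compound 4 `COc1ccc(Cn2cc(CNC(=O)c3ccc([N+](=O)[O-])o3)nn2)cc1` differs from compound 3 in one place: 4-methoxyphenyl in place of 4-hydroxy-3-methoxyphenyl on a saturated chain carbon bound to an aromatic nitrogen. The steps measured so far bear on this change only loosely. The step of a 1.0-fold higher number from compound 1 to compound 2 (0.00 log units; within the scatter) and the step of a 1.3-fold lower number from compound 2 to compound 3 (0.11 log units; within the scatter) both altered the group on the same saturated chain carbon, and neither moved the read-out beyond the scatter. He therefore expects the step of a 1.1-fold higher number from compound 3 to compound 4 (0.05 log units; within the scatter) to stay within the scatter as well. Compound 4 is estimated to give 250000 nM, with a range from 120000 nM to 500000 nM.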

Compound 4, half-maximal inhibitory concentration: 274000 nM
For compound 4 the middle estimate is 1.1-fold (0.04 log units) below the measured one, and the stated range covers the measured number.
By their numbers in this assay, from the lowest: compounds 3, 4, 1 and 2 (each within the scatter of the next).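

In this assay, the step of a 1.2-fold higher number from compound 3 to compound 4 (0.09 log units; within the scatter) shows that at this saturated chain carbon, losing the hydrogen-bond donor of the 4-hydroxy-3-methoxyphenyl group leaves the read-out unmoved beyond the scatter. The methoxy group on the aromatic carbon behaves likewise against nitro in the step of a 1.1-fold lower number from compound 2 to compound 4 (0.03 log units; within the scatter) and against trifluoromethyl in the step of a 1.1-fold lower number from compound 1 to compound 4 (0.02 log units; within the scatter) so all four compounds sit within the scatter at this position. No measurement at hand offers a reason for this. From the compounds shown here alone, whether an amine or a carboxylic acid on that aromatic ring would move the read-out beyond the scatter stays open.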